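From Allyl to Propyl on a Shared Core

A few compounds are considered here, and "the series" means these few. Any claim that something is new, unique, unknown or untested is made for them only; others in the source may bear on it.

Of the compounds shown here, three have been tested in an ADME assay on BEAS-2B cells (Homo sapiens) for cytotoxicity, read by MTT assay, with a stated time of 72 h; on this read-out lower numbers stand for stronger inhibition of growth and higher numbers for weaker inhibition of growth. Compound 1 `N#C[Se]c1ccc(NC(=O)OCc2ccc([N+](=O)[O-])cc2)cc1` gives 7700 nM. Compound 2 `CC(C)COC(=O)Nc1ccc([Se][Se]c2ccc(NC(=O)OCC(C)C)cc2)cc1` gives 13100 nM. Compound 3 `C=CCOC(=O)Nc1ccc([Se]C#N)cc1` gives 21400 nM. Of the three numbers, that of compound 3 is the largest, but its gap to compound 2 lies within the usual scatter of repeated measurements, so those two cannot be placed in any order; only its gap to compound 1 lies beyond the scatter, so compound 3 does inhibit growth more weakly than compound 1. No two of these compounds differ in a single place, so no measured step is available to guide the next move.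

The next compound, compound 4 `CCCOC(=O)Nc1ccc([Se]C#N)cc1`, differs from compound 3 in one place: ethyl in place of vinyl on a saturated chain carbon bound to an oxygen next to a carbonyl group. Read one bond further out, this is allyl becoming propyl, or allyloxy becoming propoxy. Nothing in the measured set shows what such a small change does here, so the expected step from compound 3 to compound 4 in this assay is a 1.1-fold lower number from compound 3 to compound 4 (0.03 log units; within the scatter), that is, no change beyond the scatter. Compound 4 is therefore estimated at 20000 nM, with a likely range from 8000 nM to 50000 nM.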

Compound 4, concentration for 50% growth inhibition: 19200 nM
Beside the measured number, compound 4's estimate is 1.0-fold (0.02 log units) above it; the measured number falls inside the stated range.
By their numbers in this assay, from the lowest: compounds 1, 2, 4 and 3 (each within the scatter of the next, the first and the last beyond it).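

Going by these compounds alone, this is the first measured step in the set: in this assay, ethyl in place of vinyl on a saturated chain carbon bound to an oxygen next to a carbonyl group gives a 1.1-fold lower number from compound 3 to compound 4 (0.05 log units; within the scatter), which lies within the scatter. The vinyl group carries a double bond and the ethyl group does not, yet the two numbers cannot be told apart, so for this one pair on the shared core, the double bond makes no difference that this read-out can detect. No measurement that could explain this result is available.

The compounds shown leave open whether a longer chain such as hexyl, or a chain ending in an amine or a carboxylic acid, would also leave the number within the scatter at this place. One pair also cannot show whether allyl to propyl would read the same way on the core of compound 2 or in any other setting.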